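Cytotoxicity notes on a three-ring series: the benzyl variant

The source may report more compounds than this note shows. Statements on the series, on what has been measured and on what is new or still open speak of the compounds shown alone.

Measured compounds in an ADME assay on PANC-1 cells (Homo sapiens) for cytotoxicity, read by MTT assay; on this read-out higher numbers stand for lower toxicity in this test and lower numbers for higher toxicity in this test:
- compound 1 `Cc1nc(-c2cccnc2)sc1-c1nnc(-c2ccncc2)o1` gives > 100 ug/mL, a limit of the assay.
- compound 2 `Cc1ccc(-c2nnc(-c3sc(-c4cccnc4)nc3C)o2)cc1` gives > 100 ug/mL, also only a limit.
- compound 3 `Cc1ccccc1-c1nnc(-c2sc(-c3cccnc3)nc2C)o1` gives > 100 ug/mL, again a limit and not a number.

Compound 3 therefore stands where every measured value of the series stands: at the limit of > 100 ug/mL in this assay, at which 3 of the 3 values shown sit. For the measured compounds named here, no value is a number, so no compound can be set above or below another. The step that the two limits leave unreadable from compound 1 to compound 2 is unreadable, as are a step that the two limits leave unreadable from compound 1 to compound 3 and a step that the two limits leave unreadable from compound 2 to compound 3; each joins two limits.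

Compound 4 `Cc1nc(-c2cccnc2)sc1-c1nnc(Cc2ccccc2)o1` is not yet measured. It differs from compound 3 by benzyl in place of 2-methylphenyl on an aromatic carbon.

Of the measured steps, those reaching compound 3 are the ones that bear on this change, and none of them has a readable size. Going by the values given here, there is thus no measured step that would point to a shift beyond the scatter in this assay, and none that rules one out. Compound 4 is expected to sit at the limit as well, so the estimated step of a number no higher from compound 3 to compound 4 (the limit leaves the size open) is none beyond the scatter. For compound 4 the estimate in this assay is 100 ug/mL, with a range from 50 ug/mL to 200 ug/mL.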

Compound 4, half-maximal cytotoxic concentration: > 100 ug/mL
Compound 4: only a limit was reported (the forecaster's own chance of this, stated with the estimate: 80%); the middle value lies on the limit itself.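

For the compounds shown here, no step from compound 1, compound 2 or compound 3 to compound 4 can be read in this assay, because all the values are limits and not numbers: the limit of > 100 ug/mL in this assay, at which 4 of the 4 values shown sit.

The compounds shown leave open whether the benzyl, 2-methylphenyl, 4-methylphenyl and pyridin-4-yl variants differ at all in cytotoxicity, and at what concentration any of them would reach the half-maximal cytotoxic effect.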